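Swapping the Aryl Group on the Sulfonyl Sulfur

The source may hold more compounds than are shown below. What is called first, only, known or untested is meant among the compounds shown, and "the series" means these compounds.

Of the compounds shown here, two have been tested in a functional assay on MDA-MB-231 cells (Homo sapiens) for antiproliferative activity, read by MTT assay, with a stated time of 72 h; on this read-out lower numbers stand for stronger inhibition and higher numbers for weaker inhibition.

Compound 1 `NS(=O)(=O)c1ccc(S(=O)(=O)Nc2cccc(-c3nc(-c4ccc(NC(=O)c5cccnc5)cc4Cl)no3)c2)cc1`: in this assay compound 1 gives > 10000 nM, which is a limit of the assay rather than a number.

Compound 2 `CC(=O)Nc1ccc(S(=O)(=O)Nc2cccc(-c3nc(-c4ccc(NC(=O)c5cccnc5)cc4Cl)no3)c2)cc1C`: in this assay compound 2 gives > 10000 nM, which is again a limit of the assay and not a number.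

Compound 2 therefore stands only at a limit, and both values shown sit at that same limit (the limit of > 10000 nM in this assay, at which 2 of the 2 values shown sit). The step that the two limits leave unreadable from compound 1 to compound 2 exchanges one group on the sulfonyl sulfur for another, but its size cannot be read, since both of its ends are limits.

Compound 3 `CNC(=O)Nc1ccc(S(=O)(=O)Nc2cccc(-c3nc(-c4ccc(NC(=O)c5cccnc5)cc4Cl)no3)c2)cc1` carries the change (4-((methylcarbamoyl)amino)phenyl in place of 4-acetamido-3-methylphenyl on a sulfonyl sulfur). Among the measured compounds shown here, the only measured step that touches a group on the sulfonyl sulfur is this unreadable one, so nothing among the measured compounds suggests that a change at this place would bring the read-out below the limit. Compound 3 is therefore expected to stay at the limit as well, and the expected step that the limit leaves unreadable from compound 2 to compound 3 is taken as none beyond the scatter. The estimate for compound 3 is 15000 nM, within a range from 4000 nM to 60000 nM.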

Compound 3, half-maximal inhibitory concentration: 1300 nM
Estimate against measurement, compound 3: 12-fold (1.06 log units) above; measured number outside the range, below it.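

The group on the sulfonyl sulfur can move the read-out in this assay after all: 4-((methylcarbamoyl)amino)phenyl in place of 4-acetamido-3-methylphenyl gives an at least 7.6-fold lower number from compound 2 to compound 3 (0.88 log units; beyond the scatter). With the same core, (methylcarbamoyl)amino in place of sulfamoyl on an aromatic carbon gives an at least 7.6-fold lower number from compound 1 to compound 3 (0.88 log units; beyond the scatter), and both steps give only a minimum size, as each starts from a limit of the assay rather than a number. Compound 3 is thus the only compound here with a measured number, which makes it the first point in this short set from which further changes can be read in both directions, while the other two stay at: the limit of > 10000 nM in this assay, at which 2 of the 3 values shown sit.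

From the compounds shown here alone, whether the lower number comes from the (methylcarbamoyl)amino group itself or from losing the methyl on the ring stays open, and a 4-acetamidophenyl group on the sulfonyl sulfur would separate the two. Going by these compounds, how a simple amine or a carboxylic acid would read on that ring, or a longer chain in place of the methyl of the (methylcarbamoyl)amino group, is also open, and the step between the two compounds at the limit still cannot be read.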